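This account rests on a few compounds, and the source may have more. Where it says the series, first, only, none or still open, it means among the compounds named here.

Compound 1, `COc1cccc2cc(-c3nn[nH]n3)cnc12`: > 25 mg/kg
Compound 2, `COc1ccc(OC)c2ncc(-c3nn[nH]n3)cc12`: > 50 mg/kg

In a functional assay on the whole organism (strain Sprague-Dawley) for inhibition, with Rattus norvegicus as the target (on this read-out higher numbers stand for an effect only at larger amounts of compound and lower numbers for an effect already at smaller amounts), compound 1 gives > 25 mg/kg, which is a limit of the assay rather than a measured number. Compound 2 in the same assay gives > 50 mg/kg, again only a limit. Because both values sit at limits, as the limit of > 25 mg/kg in this assay, at which 1 of the 2 values shown sits, and the limit of > 50 mg/kg in this assay, at which 1 of the 2 values shown sits, show, the step that the two limits leave unreadable from compound 1 to compound 2 cannot be read, and compound 1 therefore stands only at a limit on the numbers shown, with no readable step leading away from it.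

Compound 3 is `Cc1cccc2cc(-c3nn[nH]n3)cnc12`. Its difference from compound 1 is methyl in place of methoxy on an aromatic carbon. Among the measured compounds shown here, no measured step bears on this change: the single step that has been measured, methoxy in place of hydrogen on an aromatic carbon, is itself unreadable. There is thus no basis for expecting a step in this assay in either direction beyond the scatter, and the likeliest outcome is that compound 3 is also reported only as a limit. Compound 3 is expected at 40 mg/kg, with a range from 15 mg/kg to 120 mg/kg. The step that the limit leaves unreadable from compound 1 to compound 3 that this estimate implies is expected to be none beyond the scatter.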

Compound 3, minimum effective dose: 25 mg/kg
Estimate against measurement, compound 3: 1.6-fold (0.20 log units) above, within the range that was stated.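

In this assay compound 3 gives 25 mg/kg, the first true number among the compounds shown, so with methyl on this aromatic carbon of the shared core an effect is actually recorded at a stated dose. The change from methoxy to methyl can be described only as a number no higher from compound 1 to compound 3 (the limit leaves the size open), which gives a direction but no size. Compound 1 gives > 25 mg/kg, and this remains a limit, so the two compounds cannot be set apart by any measured amount: the limit of > 25 mg/kg in this assay, at which 1 of the 3 values shown sits.

Among the compounds shown here, with only one true number, it remains open whether methyl truly improves on methoxy here or whether the two would prove alike if compound 1 had an exact value. Also open, as far as these compounds go, is how a different group on this same carbon, such as an amine, a chlorine atom or a longer chain like propyl, would shift the minimum effective dose, and so whether this position can yield an effect at smaller amounts of compound.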